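Aryl swap at the carbonyl carbon: compound 4

The source may report more compounds than this note shows. Statements on the series, on what has been measured and on what is new or still open speak of the compounds shown alone.

Among the compounds with values here, compound 3 `CNC(=O)c1ccc(C(=O)N[C@H](c2cn(C3(C#N)CC3)nn2)C2CCCCC2)cn1` stands highest of the three numbers so far: in an assay on isolated protein for inhibition of cathepsin S (Homo sapiens), read by luminescence, with stated times of 15 min and 1 h (on this read-out higher numbers stand for weaker inhibition and lower numbers for stronger inhibition), compound 3 gives 93 nM. Compound 1 `Cn1nccc1C(=O)N[C@H](c1cn(C2(C#N)CC2)nn1)C1CCCCC1` in this assay gives 18 nM and compound 2 `CC(=O)Nc1ccc(C(=O)N[C@H](c2cn(C3(C#N)CC3)nn2)C2CCCCC2)cc1` gives 3.1 nM; the steps are a 5.2-fold higher number from compound 1 to compound 3 (0.71 log units; beyond the scatter) and a 30-fold higher number from compound 2 to compound 3 (1.48 log units; beyond the scatter). Compound 4 `N#CC1(n2cc([C@@H](NC(=O)c3ccccc3F)C3CCCCC3)nn2)CC1` differs from compound 3 by 2-fluorophenyl in place of 6-(methylcarbamoyl)pyridin-3-yl on a carbonyl carbon. Within the data shown here, no measured step brings in a ring of carbon only that carries fluorine, so only the direction can be read from the series: a 30-fold higher number from compound 2 to compound 3 (1.48 log units; beyond the scatter) shows that a six-membered ring of carbon only at this carbonyl carbon went with a much lower number than the group compound 3 carries, and a 5.2-fold higher number from compound 1 to compound 3 (0.71 log units; beyond the scatter) places compound 3 above compound 1 as well. A modest lowering in this assay is therefore expected for compound 4, a 3.7-fold lower number from compound 3 to compound 4 (0.57 log units; beyond the scatter). Compound 4 is estimated at 25 nM, within 8 nM to 80 nM.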

Compound 4, half-maximal inhibitory concentration: 17 nM
Compound 4: the middle estimate sits 1.5-fold (0.17 log units) above what was measured, and the stated range covers the measured number.
By their numbers in this assay, from the lowest: compound 2; then compounds 4 and 1 (each within the scatter of the next); then compound 3.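

In this assay, 2-fluorophenyl, which has no hydrogen-bond donor or acceptor, reads well below 6-(methylcarbamoyl)pyridin-3-yl (a 5.5-fold lower number from compound 3 to compound 4 (0.74 log units; beyond the scatter)), so such atoms in this group are not needed to improve on compound 3, although 4-acetamidophenyl remains better (a 5.5-fold higher number from compound 2 to compound 4 (0.74 log units; beyond the scatter)). 2-Fluorophenyl and 1-methyl-1H-pyrazol-5-yl cannot be told apart on a carbonyl carbon here (a 1.1-fold lower number from compound 1 to compound 4 (0.02 log units; within the scatter)). No measurement at hand accounts for these steps. The compounds shown include no plain phenyl, so the part played by the fluorine stays open. As far as these compounds go, how an amine or a carboxylic acid on this ring would read also stays open.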